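Changing the Ring on the Double-Bonded Nitrogen of Compound 3

The source may report more compounds than this note shows. Statements on the series, on what has been measured and on what is new or still open speak of the compounds shown alone.

Of the compounds shown here, three built on one shared core have been measured in an ADME assay on the whole organism (Rattus norvegicus) for pharmacokinetics, using cassette dosing, at a dose of 1 mg/kg by the oral route; on this read-out lower numbers stand for lower oral bioavailability and higher numbers for higher oral bioavailability. Compound 1 `Cc1ccc(Cn2c(=O)n(C[C@H](C)C(=O)O)c(=O)[nH]/c2=N\c2ccc(OC(C)C)c(Cl)c2)cc1` gives 73.1%. Compound 2 `CC(C)Oc1ccc(/N=c2\[nH]c(=O)n(CC(C)(C)C(=O)O)c(=O)n2Cc2ccc(Cl)cc2)cc1Cl` gives 85.3%. Compound 3 `CC(C)Oc1ccc(/N=c2\[nH]c(=O)n(C[C@H](C)C(=O)O)c(=O)n2Cc2ccc(Cl)cc2)cc1Cl` gives 82.4%, the second highest of the three numbers, yet its gap to compound 2 and its gap to compound 1 both lie within the scatter, so the three cannot really be told apart on this read-out. Two single changes lead into compound 3: a number 9.3 percentage points higher from compound 1 to compound 3 (within the scatter), and a number 2.9 percentage points lower from compound 2 to compound 3 (within the scatter). Compound 4 `C[C@@H](Cn1c(=O)[nH]/c(=N\c2ccc(OC3CCC3)cc2)n(Cc2ccc(Cl)cc2)c1=O)C(=O)O` differs from compound 3 at a third place: 4-(cyclobutyloxy)phenyl in place of 3-chloro-4-isopropoxyphenyl on a double-bonded nitrogen. Neither measured step touches the group on the double-bonded nitrogen, so there is no direct guide for this change; the only hint is that every change seen so far in this series stayed within the scatter. The step expected is therefore a number 2.4 percentage points lower from compound 3 to compound 4 (within the scatter), nothing beyond the scatter. Compound 4 is thus estimated at 80%, with a range from 62% to 95%.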

Compound 4, oral bioavailability: 54.3%
Estimate against measurement, compound 4: 25.7 percentage points above; measured number below the stated range.
By their numbers in this assay, from the lowest: compound 4; then compounds 1, 3 and 2 (each within the scatter of the next, the first and the last beyond it).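

Of the three single changes shown, only this one, at the group on the double-bonded nitrogen, goes beyond the scatter in this assay: a number 28.1 percentage points lower from compound 3 to compound 4 (beyond the scatter). The group that leaves and the group that enters both hold 11 heavy atoms and have the same counts of hydrogen-bond donors and acceptors, so those counts do not separate them; the printed differences are the lost chlorine and the new four-membered ring. Nothing shown here accounts for the drop.

This one step changes both features at once, so the compounds shown leave open how much each contributes. A 4-isopropoxyphenyl group or a 3-chloro-4-(cyclobutyloxy)phenyl group on the same nitrogen would allow the chlorine and the cyclobutyloxy group to be read separately.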